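A Second Methyl on the Aryl Group of Compound 1

This account rests on a few compounds, and the source may have more. Where it says the series, first, only, none or still open, it means among the compounds named here.

For the measured compounds named here, compound 1 `Cc1cccc(-c2onc3ccc(C(=O)O)cc23)c1` gives 1410 nM in an assay for inhibition of inositol hexakisphosphate kinase 3 (Homo sapiens), read by colorimetric assay, coupled enzyme assay and malachite green, with a stated time of 120 min, in the presence of a further agent that is not named here (a lower number here means a stronger inhibitor, a higher number a weaker inhibitor), the larger of the two numbers measured so far, though only within the scatter of compound 2 `O=C(O)c1ccc2noc(-c3cccc(Oc4ccccc4)c3)c2c1`, which gives 850 nM in this assay. Going by the values given here, that step, a 1.7-fold lower number from compound 1 to compound 2 (0.22 log units; within the scatter), is the sole measured change and does not rise above the scatter. Compound 3 `Cc1cc(C)cc(-c2onc3ccc(C(=O)O)cc23)c1` differs from compound 1 by methyl in place of hydrogen on an aromatic carbon. Among the compounds with values here, no measured step adds a methyl group, so nothing beyond the scatter is expected. Compound 3 is therefore estimated at 1410 nM, with a range from 700 nM to 2800 nM. This expectation corresponds to a step of no change at the digits printed from compound 1 to compound 3 (within the scatter).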

Compound 3, half-maximal inhibitory concentration: 2440 nM
For compound 3 the middle estimate is 1.7-fold (0.24 log units) below the measured one; the range from low to high includes it.
By their numbers in this assay, from the lowest: compounds 2, 1 and 3 (each within the scatter of the next, the first and the last beyond it).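

Putting a methyl group in place of hydrogen, meta to the methyl group already on the ring, gives the first view of this change. In this assay the result is a 1.7-fold higher number from compound 1 to compound 3 (0.24 log units; within the scatter) and so this added methyl group shifts the number by no more than repeat measurements would. No supporting measurement bears on this result. Still open, going by these compounds, is whether a longer chain such as ethyl, or an amine, at this position would give a step beyond the scatter. Also open, on these data alone, is how a methyl group on another carbon of this ring would read.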